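Swapping the Carbonyl Substituent: What to Expect for Compound 4

This account rests on a few compounds, and the source may have more. Where it says the series, first, only, none or still open, it means among the compounds named here.

compound 1 `CCCCCC(=O)c1ccc(OCCCN2CCNCC2)cc1`: 14500 nM
compound 2 `CCCCCC(=O)c1ccc(OCCCN2CCN(C(=O)OC)CC2)cc1`: 12000 nM
compound 3 `CCCCCC(=O)c1ccc(OCCCN2CCN(C(=O)C(C)C)CC2)cc1`: 29500 nM

In an assay on isolated protein for binding affinity to histamine H2 receptor (Homo sapiens) (a higher number here means a weaker inhibitor, a lower number a stronger inhibitor), compound 3 gives the highest number of the three measured compounds: a 2.0-fold higher number from compound 1 to compound 3 (0.31 log units; beyond the scatter) and a 2.5-fold higher number from compound 2 to compound 3 (0.39 log units; beyond the scatter). Compound 4 `CCCCCC(=O)c1ccc(OCCCN2CCN(C(=O)CSCC)CC2)cc1` differs from compound 3 by (ethylsulfanyl)methyl in place of isopropyl on a carbonyl carbon. The step that bears most directly on this change is the one on the same carbonyl carbon, a 2.5-fold higher number from compound 2 to compound 3 (0.39 log units; beyond the scatter), which was modest; the other step on the ring nitrogen, a 1.2-fold lower number from compound 1 to compound 2 (0.08 log units; within the scatter), stayed within the scatter. Within the data shown here, the data give no direct precedent for the entering group, so compound 4 is expected to sit close to compound 3, with at most a modest shift in either direction, a 1.2-fold lower number from compound 3 to compound 4 (0.07 log units; within the scatter). Compound 4 is estimated at 25000 nM, within a range of 10000 nM to 60000 nM.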

Compound 4, inhibition constant: 22900 nM
Compound 4: the middle estimate sits 1.1-fold (0.04 log units) above what was measured; the range from low to high includes it.
By their numbers in this assay, from the lowest: compounds 2, 1, 4 and 3 (each within the scatter of the next, the first and the last beyond it).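

In this assay, (ethylsulfanyl)methyl in place of isopropyl on a carbonyl carbon brings a sulfur-bearing chain to this position without a shift beyond the scatter (a 1.3-fold lower number from compound 3 to compound 4 (0.11 log units; within the scatter)). The other two new steps also stay within the scatter (a 1.9-fold higher number from compound 2 to compound 4 (0.28 log units; within the scatter) and a 1.6-fold higher number from compound 1 to compound 4 (0.20 log units; within the scatter)), whereas the matching steps that end at compound 3 lie beyond it. Nothing available explains these small differences. As far as these compounds go, whether an amine, a carboxylic acid or a longer chain on this carbonyl carbon would move the number beyond the scatter remains open.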